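Ester tail variation on the shared core and cytotoxicity

The source may report more compounds than this note shows. Statements on the series, on what has been measured and on what is new or still open speak of the compounds shown alone.

Compound 2 `O=C(OCCc1c(-c2ccccc2Cl)c2cc(Cl)ccc2[nH]c1=O)c1ccccc1` carries a benzoate ester on the shared core. In an ADME assay on HepG2 2.2.15 cells (Homo sapiens) for cytotoxicity (on this read-out higher numbers stand for lower toxicity in this test and lower numbers for higher toxicity in this test), compound 2 gives 43000 nM, the lower of the two numbers recorded so far. Going by the values given here, the only measured neighbour is compound 1 `N#CCC(=O)OCCc1c(-c2ccccc2Cl)c2cc(Cl)ccc2[nH]c1=O`, which in this assay gives 100000 nM; the step of a 2.3-fold lower number from compound 1 to compound 2 (0.37 log units; beyond the scatter) shows that replacing cyanomethyl with phenyl on the carbonyl carbon moved the read-out to a lower number.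

Compound 3 `COc1ccccc1/C=C/C(=O)OCCc1c(-c2ccccc2Cl)c2cc(Cl)ccc2[nH]c1=O` is not yet measured. It differs from compound 2 by 2-(2-methoxyphenyl)ethenyl in place of phenyl on a carbonyl carbon. Among the compounds with values here, the single measured step above concerns a change on the same carbonyl carbon, but exchanges an unrelated group, so it bears on compound 3 only loosely; no step with an ethenyl-linked or methoxy-bearing group exists in this set. Within the data shown here, on that basis only a modest movement, if any, is expected in this assay for compound 3, leaning toward a lower number as in the one measured step, with wide uncertainty. Compound 3 is therefore estimated at 30000 nM, in the range 10000 nM to 100000 nM, an expected step of a 1.4-fold lower number from compound 2 to compound 3 (0.16 log units; within the scatter).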

Compound 3, half-maximal cytotoxic concentration: 770000 nM
Estimate against measurement, compound 3: 26-fold (1.41 log units) below, outside the stated range (above it).
By their numbers in this assay, from the lowest: compound 2; then compound 1; then compound 3.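

In this assay, the ester tail on this carbonyl carbon turns out to be far more sensitive than the first pair suggested: there is an 18-fold higher number from compound 2 to compound 3 (1.25 log units; beyond the scatter), against only a 2.3-fold lower number from compound 1 to compound 2 (0.37 log units; beyond the scatter) in the opposite direction. Set against cyanomethyl, 2-(2-methoxyphenyl)ethenyl also gives a 7.7-fold higher number from compound 1 to compound 3 (0.89 log units; beyond the scatter), so among these three compounds it is the tail with the highest number, and both of its steps are beyond the scatter. Phenyl and 2-(2-methoxyphenyl)ethenyl each carry one six-membered aromatic ring of carbon only, so that ring alone does not set the read-out at this position, as compound 2 and compound 3 share it and still lie far apart. Nothing at hand bears on why the number rises with this change.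

Open, as far as these compounds go, is whether the ethenyl link or the methoxy group carries the change, as compound 3 brings in both at once. A 2-phenylethenyl tail would separate the two, and a tail ending in an amine or a carboxylic acid would show whether the trend at this position extends to charged groups.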